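This account rests on a few compounds, and the source may have more. Where it says the series, first, only, none or still open, it means among the compounds named here.

Measured compounds:
compound 1 `CCCNC(=O)c1ccc(Oc2nc(-c3c(C)noc3C)cnc2N)cc1` – 17500 nM
compound 2 `Cc1noc(C)c1-c1cnc(N)c(Oc2ccc(C(=O)NC3CC3)cc2)n1` – reported only as a limit, > 100000 nM

In a functional assay on LoVo cells (Homo sapiens) for inhibition, read by MTT assay, with a stated time of 72 h (a higher number here means a weaker inhibitor, a lower number a stronger inhibitor), compound 1 gives 17500 nM. For compound 2 this assay returns only a limit, > 100000 nM, so its position is known merely as a bound the limit of > 100000 nM in this assay, at which 1 of the 2 values shown sits, rather than as a number. Among the measured compounds shown here, the one measured step is an at least 5.7-fold higher number from compound 1 to compound 2 (0.75 log units; beyond the scatter).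

Compound 3 `Cc1noc(C)c1-c1cnc(N)c(Oc2ccc(C(=O)NC3CCCC3)cc2)n1` differs from compound 2 by cyclopentyl in place of cyclopropyl on an amide-type nitrogen. For the measured compounds named here, no measured step covers cyclopentyl directly; the only bearing is that the step from a propyl chain to the smaller cyclopropyl weakened inhibition, and cyclopentyl moves back toward a bulkier group of the size of propyl. Compound 3 is therefore expected to give a number rather than a limit, with the step of an at least 2.5-fold lower number from compound 2 to compound 3 (0.39 log units; beyond the scatter) expected in the direction of stronger inhibition, though a second limit remains plausible. The estimate for compound 3 in this assay is 40000 nM, range 8000 nM to 200000 nM.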

Compound 3, half-maximal inhibitory concentration: 25200 nM
Estimate against measurement, compound 3: 1.6-fold (0.20 log units) above, and the stated range covers the measured number.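

In this assay, replacing cyclopropyl with cyclopentyl on the amide-type nitrogen restores a measurable number (an at least 3.9-fold lower number from compound 2 to compound 3 (0.59 log units; beyond the scatter)), so the loss seen with cyclopropyl does not extend to every cycloalkyl group at this position. Propyl and cyclopentyl cannot be told apart here (a 1.4-fold higher number from compound 1 to compound 3 (0.16 log units; within the scatter)), which means that, among the three groups shown, only cyclopropyl stands apart, and a ring as such carries no penalty. Compound 2 stands only as a limit, so the first of these steps is a bound and not a measured size: the limit of > 100000 nM in this assay, at which 1 of the 3 values shown sits.

Open, from the compounds shown here alone, is whether any group on this nitrogen can go beyond the level shared by propyl and cyclopentyl, for instance a longer chain or a cyclohexyl ring. Also open, going by these compounds, is how a chain ending in an amine or a carboxylic acid would read here.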